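The compounds below may be only part of what the source reports. "The series", "measured", "known", "first", "only" and "open" are said of these compounds alone.

Compound 1 `C=C1C(=O)[C@@]23C(=O)OC[C@]4(C(=O)CCC(C)(C)[C@H]4C=O)[C@@H]2CC[C@@H]1[C@H]3OC(C)=O`: 1660 nM
Compound 2 `C=C1C(=O)[C@@]23C(=O)OC[C@]4(C(=O)CCC(C)(C)[C@H]4C=O)[C@@H]2CC[C@@H]1[C@H]3OC(=O)c1ccc(C)cc1`: 2240 nM
Compound 3 `C=C1C(=O)[C@@]23C(=O)OC[C@]4(C(=O)CCC(C)(C)[C@H]4C=O)[C@@H]2CC[C@@H]1[C@H]3OC(=O)c1ccc([N+](=O)[O-])cc1`: 3330 nM

These values come from a functional assay on MGC-803 cells (Homo sapiens) for cytotoxicity, read by MTT assay, with a stated time of 72 h; on this read-out lower numbers stand for stronger inhibition and higher numbers for weaker inhibition. The three compounds share one core and differ only in the group on a carbonyl carbon. Compound 2 lies close to both of the others, with a 1.3-fold higher number from compound 1 to compound 2 (0.13 log units; within the scatter) on one side and a 1.5-fold higher number from compound 2 to compound 3 (0.17 log units; within the scatter) on the other. The remaining step, a 2.0-fold higher number from compound 1 to compound 3 (0.30 log units; within the scatter), also stays within the usual spread, so the three values cannot be ranked.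

Compound 4 `C=C1C(=O)[C@@]23C(=O)OC[C@]4(C(=O)CCC(C)(C)[C@H]4C=O)[C@@H]2CC[C@@H]1[C@H]3OC(=O)c1ccc(Cl)cc1` comes from compound 2 by a single change: chloro in place of methyl on an aromatic carbon. This places chloro in place of methyl on an aromatic carbon, para to a large group. The measured step closest to this one is at the same place, where nitro in place of methyl gave a 1.5-fold higher number from compound 2 to compound 3 (0.17 log units; within the scatter). Replacing methyl with 4-methylphenyl gave a 1.3-fold higher number from compound 1 to compound 2 (0.13 log units; within the scatter), and replacing it with 4-nitrophenyl gave a 2.0-fold higher number from compound 1 to compound 3 (0.30 log units; within the scatter). None of these steps exceeds the scatter, so no clear shift is expected in this assay. Within the data shown here, the expected change is a 1.2-fold higher number from compound 2 to compound 4 (0.06 log units; within the scatter), which would be no real step at all. For compound 4 the estimated value is 2600 nM, with an expected range from 1300 nM to 5000 nM.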

Compound 4, half-maximal inhibitory concentration: 3120 nM
Compound 4: middle estimate off by 1.2-fold (0.08 log units), on the low side, and the stated range covers the measured number.
By their numbers in this assay, from the lowest: compounds 1, 2, 4 and 3 (each within the scatter of the next).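

In this assay, chloro in place of methyl on the aromatic carbon para to a large group gave a 1.4-fold higher number from compound 2 to compound 4 (0.14 log units; within the scatter), and chloro in place of nitro at the same carbon gave a 1.1-fold lower number from compound 3 to compound 4 (0.03 log units; within the scatter), so a third group at this place also stays within the scatter of the other two. On the carbonyl carbon, 4-chlorophenyl in place of methyl gave a 1.9-fold higher number from compound 1 to compound 4 (0.27 log units; within the scatter), which makes it the third aromatic group there whose step from compound 1 does not exceed the scatter. Nothing shown gives a reason for these numbers or connects them to any property of the groups.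

The compounds shown leave open whether an amine or a carboxylic acid on this same aromatic carbon would also stay within the scatter, or would be the first group here to move the number beyond it. They also leave open whether a longer chain in place of methyl on the carbonyl carbon, or a chloro on another carbon of the aromatic ring, would give a step that can be read.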